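Fluoromethyl in place of hydrogen on compound 2

The compounds below may be only part of what the source reports. "The series", "measured", "known", "first", "only" and "open" are said of these compounds alone.

In a physicochemical assay for lipophilicity, at pH 7.4 (a lower number here means a more polar compound, a higher number a more lipophilic compound), compound 2 (`CNC(=O)c1cc(C(=O)NCCC[C@H]2OC[C@H](N)CO2)cc2c1OC[C@H]2c1ccccc1`) gives 2.6 and compound 1 (`CNC(=O)c1cc(C(N)=O)cc2c1O[C@H](CF)[C@H]2c1ccccc1`) gives 2.9 so the two stand within the scatter of each other. Compound 3 (`CNC(=O)c1cc(C(=O)NCCC[C@H]2OC[C@H](N)CO2)cc2c1O[C@H](CF)[C@H]2c1ccccc1`) differs from compound 2 by fluoromethyl in place of hydrogen on a saturated ring carbon. Among the measured compounds shown here, no measured pair isolates this change. Compound 1 also carries fluoromethyl and gives 2.9 but it differs from compound 3 elsewhere, so it offers only weak guidance. The expected step of a number 0.10 log units higher from compound 2 to compound 3 (within the scatter) is small and upward and stays within the scatter. Compound 3 is estimated at 2.7 with an expected range from 2.3 to 3.1 in this assay.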

Compound 3, distribution coefficient: 2.9
For compound 3 the middle estimate is 0.20 log units below the measured one; measured number inside the range.
By their numbers in this assay, from the lowest: compounds 2, 1 and 3 (each within the scatter of the next).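

Read on a matched pair in this assay, fluoromethyl in place of hydrogen on this saturated ring carbon gives a number 0.30 log units higher from compound 2 to compound 3 (within the scatter) and so does not separate the two compounds. With fluoromethyl present, the group of 10 heavy atoms in place of a hydrogen atom on the amide-type nitrogen gives no change at the digits printed from compound 1 to compound 3 (within the scatter) and likewise separates nothing in this assay. No measurement here bears on why these steps come out as they do.

From the compounds shown here alone, whether trifluoromethyl or hydroxymethyl on the same ring carbon would stay within the scatter of compound 2 remains open. Also open, going by these compounds, is how a longer chain on the amide-type nitrogen would read alongside fluoromethyl.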